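A stereochemical flip in a topoisomerase series

The source may hold more compounds than are shown below. What is called first, only, known or untested is meant among the compounds shown, and "the series" means these compounds.

Three compounds that share a sugar-like ring linked through an alkyne to an aromatic core have been tested in an assay on isolated protein for inhibition of DNA topoisomerase 1 (Homo sapiens), with a stated time of 30 min, tested at 100 uM; on this read-out lower numbers stand for less inhibition and higher numbers for more inhibition at the one concentration tested (going by the name of the read-out). Compound 1 `C[C@@H]1O[C@@H](OCC#Cc2c(-c3ccccc3)sc3ccccc23)C[C@H](N)[C@H]1O` gives 32.2%. Compound 2 `C[C@@H]1O[C@@H](OCC#Cc2c(-c3ccccc3)[nH]c3ccccc23)C[C@H](N)[C@@H]1O` gives 8.8%, the lowest of the three numbers; the gap to compound 1 lies beyond the scatter. Compound 3 `Cc1ccc(S(=O)(=O)n2c(-c3ccccc3)c(C#CCO[C@H]3C[C@H](N)[C@H](O)[C@H](C)O3)c3ccccc32)cc1` gives 80.1%. Among the compounds with values here, the only one-place step measured so far, a number 71.3 percentage points higher from compound 2 to compound 3 (beyond the scatter), is large and comes from placing a (4-methylphenyl)sulfonyl group on the aromatic nitrogen.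

Compound 4 `C[C@@H]1O[C@@H](OCC#Cc2c(-c3ccccc3)[nH]c3ccccc23)C[C@H](N)[C@H]1O` has not yet been measured in this assay. Its relation to compound 2 is the two compounds have the same atoms and bonds and differ only in configuration as drawn: 1 of 4 stereo elements differ; a stereocentre at a saturated ring carbon is drawn S in compound 2 and R in compound 4. Within the data shown here, no measured pair in this set differs only in configuration, so the step from compound 2 to compound 3 does not speak to this change, and there is nothing here to show whether inverting a single ring stereocentre moves the read-out at all.

With that gap in the evidence, compound 4 is expected to stay close to compound 2, with any shift most likely within the scatter, that is a number 6.2 percentage points higher from compound 2 to compound 4 (within the scatter). The estimate for compound 4 in this assay is therefore 15%, with a range from 2% to 40%.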

Compound 4, a percentage reported as inhibition, at one concentration (the size of the read-out at that concentration, not a potency): 8.2%
Beside the measured number, compound 4's estimate is 6.8 percentage points above it; low and high end bracket the measured number.
By their numbers in this assay, from the lowest: compounds 4 and 2 (each within the scatter of the next); then compound 1; then compound 3.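

Within the data shown here, compounds 2 and 4 are the first pair in this set to isolate configuration, and the comparison rests on one fact: the fact that compounds 2 and 4 differ only in the configuration as drawn. Turning this one saturated ring carbon from S to R gives a number 0.6 percentage points lower from compound 2 to compound 4 (within the scatter) in this assay, so this read-out does not tell the two arrangements apart. The finding is narrow, as it covers one stereocentre in compounds with a hydrogen on the aromatic nitrogen, and both values lie at the bottom of the four measured numbers, where there is little room to detect any further loss of inhibition.

As far as these compounds go, whether the same inversion matters with a (4-methylphenyl)sulfonyl group on that nitrogen remains open, and that is the setting in which compound 3 gives 80.1%, leaving far more room for a drop to show. Also open, from the compounds shown here alone, are the effect of inverting the other stereocentres on the sugar-like ring and how the read-out would respond to a dimethylamino group in place of the amine on that ring.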